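The source may hold more compounds than are shown below. What is called first, only, known or untested is meant among the compounds shown, and "the series" means these compounds.

Working notes on the series in a functional assay on HTB-54 cells (Homo sapiens) for cytotoxicity, read by MTT assay, with a stated time of 72 h; on this read-out higher numbers stand for weaker inhibition of growth and lower numbers for stronger inhibition of growth.

Of the compounds shown here, two have numbers so far. Compound 1 `CSc1ccc(CNc2nc([SeH])nc3ccccc23)cc1` carries a selenol on the shared core and a methylthio-bearing benzylamine; in this assay compound 1 gives 45500 nM. Compound 2 `CCCCC[Se]c1nc(NCc2ccccc2)c2ccccc2n1` carries a pentyl on the selenium and a plain benzylamine; in this assay compound 2 gives 37700 nM. On the numbers shown, compound 2 and compound 1 sit within the scatter of each other, so neither can be placed above or below the other, and both sit in the weak range of the read-out.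

Compound 3 `[SeH]c1nc(NCc2ccccc2)c2ccccc2n1` is not yet measured. Compared with compound 2, the change is hydrogen in place of pentyl on a selenium, with the selenium otherwise unchanged. Going by the values given here, no measured pair shows this step on its own, so nothing fixes its size. The nearest guide is compound 1, which also carries a selenol and gives 45500 nM; that number does not separate from compound 2. The step is therefore expected to stay within the scatter, with no direction beyond it, so that the estimated step from compound 2 to compound 3 is a 1.1-fold higher number from compound 2 to compound 3 (0.05 log units; within the scatter). For compound 3 the expected value is 42000 nM, with a range from 20000 nM to 90000 nM.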

Compound 3, concentration for 50% growth inhibition: 31200 nM
Estimate against measurement, compound 3: 1.3-fold (0.13 log units) above; measured number inside the range.
By their numbers in this assay, from the lowest: compounds 3, 2 and 1 (each within the scatter of the next).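

In this assay, going by these compounds alone, hydrogen in place of pentyl on a selenium gives a 1.2-fold lower number from compound 2 to compound 3 (0.08 log units; within the scatter) and is the first direct reading of this exchange, so a pentyl on the selenium, with its 5 carbons and no ring, does not separate from the bare selenol in this pair. Hydrogen in place of methylsulfanyl on an aromatic carbon gives a 1.5-fold lower number from compound 1 to compound 3 (0.16 log units; within the scatter) and supplies a second single-place reading at a different site, which also does not separate, so neither exchange moves the number beyond the scatter and all three compounds remain in the weak range of the read-out. No measurement at hand explains why either exchange leaves the number within the scatter.

Going by these compounds, whether a group of another kind on the selenium, such as a carboxylic acid, an amine or a chain longer than pentyl, would separate from compound 3 remains open. Equally open, on these data alone, is whether a chlorine or a methoxy in place of the methylsulfanyl on the aromatic carbon would give a step beyond the scatter from compound 3.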